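Swapping sec-butyl for cyclopropyl on a weaker series member

The source may report more compounds than this note shows. Statements on the series, on what has been measured and on what is new or still open speak of the compounds shown alone.

Measured compounds:
Compound 1 `CCC(C)N(C(=O)[C@H](CC(=O)OC)NC(=O)OC(C)(C)C)C1(C(=O)NCc2ccccc2)CCN(Cc2ccccc2)CC1` gives 16000 nM in a functional assay on HeLa cells (Homo sapiens) for inhibition, with a stated time of 72 h; on this read-out higher numbers stand for weaker inhibition and lower numbers for stronger inhibition.
Compound 2 `COC(=O)C[C@H](NC(=O)OC(C)(C)C)C(=O)N(C1CC1)C1(C(=O)NCc2ccccc2)CCN(Cc2ccccc2)CC1` gives 7900 nM in this assay.
Compound 3 `CCC(C)N(C(=O)[C@@H](NC(=O)OCc1ccccc1)[C@@H](C)CC)C1(C(=O)NCc2ccccc2)CCN(Cc2ccccc2)CC1` gives 119000 nM in this assay.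

Compound 2 differs from compound 1 by one change, (cyclopropyl in place of sec-butyl on an amide-type nitrogen), and this gave a 2.0-fold lower number from compound 1 to compound 2 (0.31 log units; beyond the scatter). Compound 3 carries a different core; the difference between the cores of compound 3 and compound 1 is not broken down here, and compound 3 has the highest number of the three measured.

Compound 4 `CC[C@H](C)[C@H](NC(=O)OCc1ccccc1)C(=O)N(C1CC1)C1(C(=O)NCc2ccccc2)CCN(Cc2ccccc2)CC1` is not yet measured. It differs from compound 3 by cyclopropyl in place of sec-butyl on an amide-type nitrogen, the same change seen between compound 1 and compound 2. Because that change gave a 2.0-fold lower number from compound 1 to compound 2 (0.31 log units; beyond the scatter), a step of similar size is expected here, estimated as a 2.0-fold lower number from compound 3 to compound 4 (0.30 log units; within the scatter), though a different core may respond differently. Compound 4 is therefore estimated at 60000 nM, expected to lie between 25000 nM and 150000 nM.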

Compound 4, half-maximal inhibitory concentration: 30000 nM
Estimate against measurement, compound 4: 2.0-fold (0.30 log units) above; the measured number falls inside the stated range.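

In this assay, putting cyclopropyl in place of sec-butyl on the amide-type nitrogen gave a 4.0-fold lower number from compound 3 to compound 4 (0.60 log units; beyond the scatter), and the number moved in the same direction on this core as on the core of compound 1. The gap between the two steps is no larger than ordinary measurement scatter, so the change carried over between these two cores without a measurable difference in size: the same change on two cores in this assay, a 2.0-fold lower number (0.31 log units; beyond the scatter) from compound 1 to compound 2 and a 4.0-fold lower number (0.60 log units; beyond the scatter) from compound 3 to compound 4, 2.0-fold (0.29 log units) apart, within the scatter of two such steps. Among the compounds shown here, this rests on only two pairs, and it shows neither why the number falls nor that it would fall on any other core.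

As far as these compounds go, whether a cyclobutyl ring, an ethyl chain or an amine on that nitrogen would give a lower number remains open.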